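Branching the alkoxy chain: compound 2 to compound 4

The compounds below may be only part of what the source reports. "The series", "measured", "known", "first", "only" and "open" are said of these compounds alone.

In an assay on cells for antagonist activity at transient receptor potential cation channel subfamily V member 1 (Homo sapiens), read by FLIPR and calcium flux, with a stated time of 6 min (a lower number here means a stronger inhibitor, a higher number a weaker inhibitor), compound 2 `CCCOc1nc(C(C)(C)C)ccc1CNC(=O)C(C)c1ccc(NS(C)(=O)=O)c(F)c1` gives 1.7 nM, the second highest of the three numbers. Compound 3 `CCCCCCOc1nc(C(C)(C)C)ccc1CNC(=O)C(C)c1ccc(NS(C)(=O)=O)c(F)c1` gives 2.7 nM, and compound 1 `CC(C(=O)NCc1ccc(C(C)(C)C)nc1N1CCC(Cc2ccccc2)CC1)c1ccc(NS(C)(=O)=O)c(F)c1`, which lacks the alkoxy group, gives 0.3 nM. Compound 4 `CC(C)COc1nc(C(C)(C)C)ccc1CNC(=O)C(C)c1ccc(NS(C)(=O)=O)c(F)c1` differs from compound 2 by methyl in place of hydrogen on a saturated chain carbon bound to two saturated chain carbons. Among the measured compounds shown here, the only measured step that bears on this change is the chain lengthening a 1.6-fold higher number from compound 2 to compound 3 (0.20 log units; within the scatter), which stayed within the scatter; no measured step tests branching at this carbon, and compound 1 offers no comparison for it. The step to compound 4 is therefore expected to stay within the scatter, a 1.2-fold higher number from compound 2 to compound 4 (0.07 log units; within the scatter). Compound 4 is estimated at 2 nM, with a range from 0.8 nM to 5 nM.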

Compound 4, inhibition constant: 0.6 nM
Estimate against measurement, compound 4: 3.3-fold (0.52 log units) above, and the stated range ends above it.
By their numbers in this assay, from the lowest: compounds 1 and 4 (each within the scatter of the next); then compounds 2 and 3 (each within the scatter of the next).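

Branching at this saturated chain carbon registers in this assay where lengthening did not: the methyl gives a 2.8-fold lower number from compound 2 to compound 4 (0.45 log units; beyond the scatter), whereas a 1.6-fold higher number from compound 2 to compound 3 (0.20 log units; within the scatter) stays within the scatter. The branched chain also separates from the longer straight chain, with a 4.5-fold lower number from compound 3 to compound 4 (0.65 log units; beyond the scatter), so among these three compounds the alkoxy position responds to chain shape and not only to chain length. No evidence is available to explain this difference. Open, as far as these compounds go, is whether a cyclopropylmethoxy group would match isobutoxy, and whether an amine at the chain end would be tolerated.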